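Cyano in place of trifluoromethyl in compound 2

The compounds below may be only part of what the source reports. "The series", "measured", "known", "first", "only" and "open" are said of these compounds alone.

In a functional assay on HL-60 cells (Homo sapiens) for cytotoxicity, read by luminescence and CellTiter-Glo, with a stated time of 3 days (on this read-out lower numbers stand for stronger inhibition and higher numbers for weaker inhibition), compound 2 `O=C(Nc1ccc(C(F)(F)F)cc1)c1cc(Br)ccc1O` gives 580 nM. Compound 1 `N#Cc1ccc(NC(=O)c2cc(Cl)ccc2O)cc1` gives 700 nM and compound 3 `O=C(Nc1ccc(C(F)(F)F)cc1)c1cc(Br)c(-c2ccccc2)cc1O` gives 540 nM. Compound 2 therefore stands among three numbers that all lie within the scatter of one another.

The unmeasured compound 4 `N#Cc1ccc(NC(=O)c2cc(Br)ccc2O)cc1` departs from compound 2 in one group: cyano in place of trifluoromethyl on an aromatic carbon. This is cyano in place of trifluoromethyl on an aromatic carbon, para to a large group.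

Among the compounds with values here, no measured step makes this exchange. Within the data shown here, the only step available, a 1.1-fold lower number from compound 2 to compound 3 (0.03 log units; within the scatter), is a different change, phenyl in place of hydrogen on an aromatic carbon, and it bears on the question only by showing how little separates these compounds so far. Among the measured compounds shown here, the closest guide is compound 1, the one measured compound that also carries cyano, with its 700 nM within the scatter of the value of compound 2. On this evidence, no step beyond the scatter is expected in this assay. The expected step is a 1.1-fold higher number from compound 2 to compound 4 (0.04 log units; within the scatter). Compound 4 is estimated at 640 nM, with an expected range from 300 nM to 1300 nM.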

Compound 4, half-maximal inhibitory concentration: 620 nM
The estimate for compound 4 lay 1.0-fold (0.01 log units) above the measured number; the range from low to high includes it.
By their numbers in this assay, from the lowest: compounds 3, 2, 4 and 1 (each within the scatter of the next).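

In this assay, the exchange of trifluoromethyl for cyano on this aromatic carbon, para to a large group, can now be read directly, with the rest of the structure held constant: a 1.1-fold higher number from compound 2 to compound 4 (0.03 log units; within the scatter). The earlier compounds shown here could not show this, since compound 1 differs from compound 2 in both the cyano group and the halogen, and compound 4 separates the two changes, with bromo in place of chloro giving a 1.1-fold lower number from compound 1 to compound 4 (0.05 log units; within the scatter). Neither exchange moves the number beyond the scatter, and nothing available here offers an explanation for that.

What the compounds shown leave open is whether this position tolerates any group beyond trifluoromethyl and cyano, such as an amine, a carboxylic acid or a longer alkyl chain, or whether the narrow spread simply reflects how similar these two groups are in this setting. As far as these compounds go, it is also open whether the exchange of trifluoromethyl for cyano would read the same way on the phenyl-bearing core of compound 3.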